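This account rests on a few compounds, and the source may have more. Where it says the series, first, only, none or still open, it means among the compounds named here.

In an ADME assay on microsomes from liver (Rattus norvegicus) for metabolic stability, with a stated time of 60 min, tested at 1 uM (a higher number here means that more of the compound is left, a lower number that less of the compound is left), three compounds have been measured so far:
Compound 1 `COc1cc(-c2cnn3cc(OC)c(-c4cnn(C)c4)nc23)ccn1` gives 56%
Compound 2 `CNc1nc2c(-c3ccnc(OC)c3)cnn2cc1OC` gives 74%
Compound 3 `COc1cc(-c2cnn3cc(OC)c(-c4cc(C)no4)nc23)ccn1` gives 62%

Compound 3 cannot be separated from compound 1 and lies clearly under compound 2. Compound 4 `COc1cc(-c2cnn3cc(OC)c(C4CCOC4)nc23)ccn1` carries oxolan-3-yl in place of 3-methyl-1,2-oxazol-5-yl on an aromatic carbon and has not yet been measured. Earlier swaps on this same carbon bear on the change: they gave a number 6 percentage points higher from compound 1 to compound 3 (within the scatter) and a number 12 percentage points lower from compound 2 to compound 3 (beyond the scatter) and also a number 18 percentage points higher from compound 1 to compound 2 (beyond the scatter). None of them brings in a non-aromatic ring, so they guide only the size, and a modest step is the most to expect. The direction is uncertain, with a slight lean downward. The expected step is a number 5 percentage points lower from compound 3 to compound 4 (within the scatter) in this assay. Compound 4 is estimated at 57% with an expected range from 38% to 74%.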

Compound 4, percent of the compound remaining: 34%
Estimate against measurement, compound 4: 23 percentage points above; measured number outside the range, below it.
By their numbers in this assay, from the lowest: compound 4; then compounds 1 and 3 (each within the scatter of the next); then compound 2.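

Oxolan-3-yl, the first non-aromatic ring on this aromatic carbon, gives the lowest number so far in this assay. Measured against the three earlier groups, the change is a number 28 percentage points lower from compound 3 to compound 4 (beyond the scatter) and also a number 22 percentage points lower from compound 1 to compound 4 (beyond the scatter) and also a number 40 percentage points lower from compound 2 to compound 4 (beyond the scatter). This position therefore reacts more strongly to this change than the earlier swaps among methylamino and the two aromatic rings showed.

No measurement at hand explains the drop. From the compounds shown here alone, whether a cyclopentyl ring, which lacks the ring oxygen, or a morpholine ring would sit as low as oxolan-3-yl remains open.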